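Alkoxy and bromo swaps on the aryloxy-imidazoline series

The compounds below may be only part of what the source reports. "The series", "measured", "known", "first", "only" and "open" are said of these compounds alone.

Measured compounds:
- compound 1, `CCOc1ccccc1OC(C)C1=NCCN1`: 0.45
- compound 2, `CC(C)Oc1ccccc1OC(C)C1=NCCN1`: 0.7
- compound 3, `CC(Oc1ccccc1Br)C1=NCCN1`: 0.87

Compound 3 stands highest of the three in an assay on CHO cells with Alpha-2C adrenergic receptor (Homo sapiens) as the target; on this read-out higher numbers stand for larger maximal responses and lower numbers for smaller maximal responses; compound 2 is nearest, and compound 1 furthest. The two steps onto the aromatic carbon are a number 0.42 higher from compound 1 to compound 3 (beyond the scatter) and a number 0.17 higher from compound 2 to compound 3 (beyond the scatter); the step along the chain is a number 0.25 higher from compound 1 to compound 2 (beyond the scatter). Both moves from an alkoxy group to bromo on the aromatic carbon raised the maximal response, the smaller alkoxy group by more than the larger one.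

Compound 4, `C=COc1ccccc1OC(C)C1=NCCN1`, is the next member. It differs from compound 3 as follows: vinyloxy in place of bromo on an aromatic carbon. The change reverses the bromo-for-alkoxy pattern that carried compound 1 and compound 2 up to compound 3, so a fall in this assay is expected rather than a rise, probably of a size between those two measured steps, since vinyloxy resembles ethoxy and isopropoxy more than bromo. Compound 4 is therefore estimated at 0.6 in this assay, within a range of 0.4 to 0.8, which means an expected step of a number 0.27 lower from compound 3 to compound 4 (beyond the scatter).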

Compound 4, intrinsic activity: the largest response reached, as a fraction of the reference agonist's: 0.48
Compound 4: the middle estimate sits 0.12 above what was measured; the range from low to high includes it.
By their numbers in this assay, from the lowest: compounds 1 and 4 (each within the scatter of the next); then compound 2; then compound 3.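

In this assay, vinyloxy in place of bromo on the aromatic carbon gives a number 0.39 lower from compound 3 to compound 4 (beyond the scatter), so compound 3 now stands above all three oxygen-linked groups shown at this position, and the advantage of bromo is not confined to groups with a saturated chain on the oxygen. Among those groups, vinyl in place of ethyl on the oxygen gives a number 0.030 higher from compound 1 to compound 4 (within the scatter), so the double bond brings no readable change against ethyl, while vinyl in place of isopropyl gives a number 0.22 lower from compound 2 to compound 4 (beyond the scatter), which leaves isopropyl as the one group on the oxygen that stands apart from the other two. No supporting data bear on the reason for these differences.

As far as these compounds go, whether the lead of compound 3 belongs to bromo alone or extends to chloro or iodo on the same aromatic carbon remains open. From the compounds shown here alone, it is also open whether a branched chain larger than isopropyl, such as tert-butyl, on the oxygen would raise the maximal response further, and how a cyclopropyl group there would compare with vinyl and isopropyl.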